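The compounds below may be only part of what the source reports. "The series", "measured", "known", "first", "only" and "open" are said of these compounds alone.

Compound 1 `CCC(C)n1ccc2cc(/C(C)=C/C(=O)Nc3ccccc3OCCCC(=O)O)ccc21` and compound 2 `C/C(=C\C(=O)Nc1ccccc1OCCCC(=O)O)c1ccc2c(ccn2Cc2ccccc2C)c1` share one core and were both tested in an assay on Prostate gland for inhibition of steroid 5-alpha-reductase (Rattus norvegicus); a lower number here means a stronger inhibitor, a higher number a weaker inhibitor. Compound 1 gives 67 nM, and compound 2 gives 69 nM; the step of a 1.0-fold higher number from compound 1 to compound 2 (0.01 log units; within the scatter) is within the scatter, so compound 2 stands alongside compound 1 with no order between them. Compound 3 `C/C(=C\C(=O)Nc1ccccc1OCCCC(=O)O)c1ccc2c(ccn2C(c2ccccc2)C(C)C)c1` carries the change (2-methyl-1-phenylpropyl in place of 2-methylbenzyl on an aromatic nitrogen). Within the data shown here, the only measured step at the same aromatic nitrogen, sec-butyl to 2-methylbenzyl, moved nothing beyond the scatter, so a step of about a 1.0-fold higher number from compound 2 to compound 3 (0.01 log units; within the scatter) is expected, none beyond the scatter. Compound 3 is therefore estimated at 70 nM, within 35 nM to 140 nM.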

Compound 3, half-maximal inhibitory concentration: 25 nM
The estimate for compound 3 lay 2.8-fold (0.45 log units) above the measured number; measured number outside the range, below it.
By their numbers in this assay, from the lowest: compound 3; then compounds 1 and 2 (each within the scatter of the next).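

This aromatic nitrogen does respond to its substituent: 2-methyl-1-phenylpropyl gives a 2.8-fold lower number from compound 2 to compound 3 (0.44 log units; beyond the scatter) in this assay and a 2.7-fold lower number from compound 1 to compound 3 (0.43 log units; beyond the scatter) in the same this assay test, although the earlier swap at this nitrogen stayed within the scatter. Carrying a six-membered aromatic ring is not enough by itself, since 2-methylbenzyl has one and sec-butyl has none, yet those two stand level. Nothing available explains this step. Still open, on these data alone, is whether the step needs both the ring and the branching of 2-methyl-1-phenylpropyl, which a plain benzyl or a cyclohexyl group could test. An amine on this substituent is also untested territory.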